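Benzoyl swap on the compound 1 scaffold: working notes

The source may report more compounds than this note shows. Statements on the series, on what has been measured and on what is new or still open speak of the compounds shown alone.

Measured in a functional assay on SMMC-7721 cells (Homo sapiens) for inhibition, read by CCK-8 assay, with a stated time of 72 h; a higher number here means a weaker inhibitor, a lower number a stronger inhibitor:
- compound 1 (`Nc1ccccc1NC(=O)c1ccc(CNC(=O)c2n[nH]cc2NC(=O)c2ccccc2)cc1`) gives 6620 nM
- compound 2 (`O=C(NO)c1ccc(CNC(=O)c2n[nH]cc2NC(=O)c2ccccc2Cl)cc1`) gives 21800 nM

Compound 1 (6620 nM) holds the lower of the two numbers and is the stronger inhibitor of the pair, while compound 2 (21800 nM) lies higher by a gap beyond the usual scatter. Within the data shown here, no measured pair differs in one place only, so the series offers no direct step to read across.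

Compound 3 (`Nc1ccccc1NC(=O)c1ccc(CNC(=O)c2n[nH]cc2NC(=O)c2c(F)cccc2F)cc1`) has not yet been measured. It keeps the core of compound 1 and carries 2,6-difluorophenyl in place of phenyl on a carbonyl carbon. Among the measured compounds shown here, with no measured precedent for this change, the expectation in this assay stays anchored on compound 1 (6620 nM). A small shift toward a lower number is expected, not beyond the usual scatter. The estimated step (a 1.3-fold lower number from compound 1 to compound 3 (0.12 log units; within the scatter)) reflects that expectation. Compound 3 is estimated at 5000 nM, with an expected range from 1500 nM to 15000 nM.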

Compound 3, half-maximal inhibitory concentration: 15200 nM
The estimate for compound 3 lay 3.0-fold (0.48 log units) below the measured number; the whole stated range lies below it.
By their numbers in this assay, from the lowest: compound 1; then compounds 3 and 2 (each within the scatter of the next).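

In this assay, the series now has a step between compounds that differ in one place: a 2.3-fold higher number from compound 1 to compound 3 (0.36 log units; beyond the scatter). On the core of compound 1, 2,6-difluorophenyl in place of phenyl on a carbonyl carbon therefore weakens inhibition by more than the usual scatter, although the step is only modest. This position responds to a change in the ring even though the counted hydrogen-bond donors, hydrogen-bond acceptors and net charge stay the same, and the two added fluorine atoms are the only difference between the two compounds. No measurement at hand bears on the reason for this step.

Open, on these data alone, is whether a single fluorine on the phenyl ring gives a step of its own, and whether a methyl or methoxy group there would move the number in the same direction. Also open, as far as these compounds go, is how a pyridine ring in place of phenyl would read on this core, and whether the step carries over to a core other than that of compound 1.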